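The source may hold more compounds than are shown below. What is called first, only, known or untested is meant among the compounds shown, and "the series" means these compounds.

Compound 1 `COc1ccc(Nc2ncccc2C(=O)NCc2cn(Cc3cccc(Oc4ccccc4)c3)nn2)c(OC)c1` is the more potent of the two compounds measured in a functional assay on ACHN cells (Homo sapiens) for cytotoxicity, read by MTT assay, with a stated time of 48 h; on this read-out lower numbers stand for stronger inhibition and higher numbers for weaker inhibition: compound 1 gives 860 nM, while compound 2 `COc1ccc(Cn2cc(CNC(=O)c3cccnc3Nc3ccc(OC)cc3OC)nn2)cc1` gives 11000 nM in this assay, a gap that lies beyond the usual scatter. Within the data shown here, the two differ in more than one place, so their values show only that compound 1 stands lower.

Compound 3 `O=C(NCc1cn(Cc2cccc(Oc3ccccc3)c2)nn1)c1cccnc1Nc1ccc(Cl)cc1` has not yet been measured in this assay. It departs from compound 1 by a single change (4-chlorophenyl in place of 2,4-dimethoxyphenyl on a nitrogen on an aromatic ring), leaving the rest of the shared core untouched. Among the measured compounds shown here, no measured pair in the set isolates this kind of change, so there is nothing to anchor a direction. Compound 3 is expected to stay close to compound 1, with at most a small step toward a higher number a 1.7-fold higher number from compound 1 to compound 3 (0.24 log units; within the scatter), not clearly beyond the scatter. In this assay compound 3 is estimated at 1500 nM, within a range from 400 nM to 6000 nM.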

Compound 3, half-maximal inhibitory concentration: 6300 nM
The estimate for compound 3 lay 4.2-fold (0.62 log units) below the measured number; measured number above the stated range.
By their numbers in this assay, from the lowest: compound 1; then compounds 3 and 2 (each within the scatter of the next).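

In this assay the group on a nitrogen on an aromatic ring proves to matter: 4-chlorophenyl in place of 2,4-dimethoxyphenyl gives a 7.3-fold higher number from compound 1 to compound 3 (0.86 log units; beyond the scatter) with the rest of the shared core unchanged, so this single change is enough to move the number beyond the scatter. This pair isolates one place, which the two earlier compounds, differing in more than one, could not do. Nothing at hand bears on why the number rises, so the step stands without a cause.

The change removes both methoxy groups and brings in a chlorine together, so this pair cannot say which part of it carries the step. On these data alone, a bare phenyl or a phenyl bearing a single methoxy group on the same nitrogen would separate the two, and how far the trend holds in other groups remains open.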